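This account rests on a few compounds, and the source may have more. Where it says the series, first, only, none or still open, it means among the compounds named here.

Compound 1 `COc1ccc(-c2cc3ccccc3nc2/C=C/C(=O)c2ccc(O)cc2)cc1` gives 3880 nM in a functional assay on SK-BR-3 cells (Homo sapiens) for antiproliferative activity, read by XTT assay, with a stated time of 72 h; a higher number here means a weaker inhibitor, a lower number a stronger inhibitor.
Compound 2 `COc1ccc(-c2cc3ccccc3nc2/C=C/C(=O)c2ccc(OC)cc2OC)cc1` gives 2260 nM in this assay.
Compound 3 `COc1ccc(-c2cc3ccccc3nc2/C=C/C(=O)c2c(OC)cccc2OC)cc1` gives 3830 nM in this assay.

All three compounds share the same core and differ only in the aryl group attached to the carbonyl carbon. Compound 3 sits between the other two numbers, yet the gaps are small: against compound 1 the step is a 1.0-fold lower number from compound 1 to compound 3 (0.01 log units; within the scatter), and against compound 2 it is a 1.7-fold higher number from compound 2 to compound 3 (0.23 log units; within the scatter), so the three values cannot be told apart with confidence.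

Compound 4 `COc1ccc(-c2cc3ccccc3nc2/C=C/C(=O)c2ccc(N)cc2)cc1` is the next compound in this series. It differs from compound 3 in one place: 4-aminophenyl in place of 2,6-dimethoxyphenyl on a carbonyl carbon. The entering group resembles the 4-hydroxyphenyl of compound 1 more than the dimethoxyphenyl groups of compounds 2 and 3.

Every step measured so far at this carbonyl position, namely a 1.7-fold lower number from compound 1 to compound 2 (0.23 log units; within the scatter), a 1.0-fold lower number from compound 1 to compound 3 (0.01 log units; within the scatter) and a 1.7-fold higher number from compound 2 to compound 3 (0.23 log units; within the scatter), stays within the scatter. Swapping hydroxyphenyl for either dimethoxyphenyl moved nothing beyond noise, so the aryl group on the carbonyl seems to matter little in this assay for these compounds. Compound 4 is therefore expected to land near the cluster of measured values, with a step of a 1.1-fold lower number from compound 3 to compound 4 (0.04 log units; within the scatter) that is not beyond the scatter. For compound 4 the estimate in this assay is 3500 nM, within a range from 1500 nM to 8000 nM.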

Compound 4, half-maximal inhibitory concentration: 8560 nM
For compound 4 the middle estimate is 2.4-fold (0.39 log units) below the measured one, outside the stated range (above it).
By their numbers in this assay, from the lowest: compounds 2, 3 and 1 (each within the scatter of the next); then compound 4.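

For the compounds shown here, the aryl group on the carbonyl carbon is not as indifferent as the earlier compounds suggested in this assay: 4-aminophenyl in place of 2,6-dimethoxyphenyl gives a 2.2-fold higher number from compound 3 to compound 4 (0.35 log units; beyond the scatter), and in place of 2,4-dimethoxyphenyl it gives a 3.8-fold higher number from compound 2 to compound 4 (0.58 log units; beyond the scatter), and these are modest steps but the first at this position beyond the scatter. The cleanest comparison is amino in place of hydroxy on an aromatic carbon, where a 2.2-fold higher number from compound 1 to compound 4 (0.34 log units; beyond the scatter) shows that this one small exchange on the same phenyl ring is enough to move the number beyond the scatter, leaving compound 4 as the weakest of the four inhibitors. Nothing given here explains why the amino group behaves differently from the hydroxy group.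

These compounds leave open whether the higher number belongs to the free amino group itself or would persist with a dimethylamino group or an acetamide in its place. Going by these compounds alone, they also leave open how a carboxylic acid or a fluorine on this phenyl ring would compare, and so how far the sensitivity at this position extends beyond the single exchange seen here.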